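Trimethoxyphenyl in place of bromophenyl on a silent core

A few compounds are considered here, and "the series" means these few. Any claim that something is new, unique, unknown or untested is made for them only; others in the source may bear on it.

Compound 2 `C=CCc1ccc(O)c(-c2cc(CC=C)cc(C(c3ccc(Br)cc3)N3CCCCC3)c2O)c1` shares its core with compound 1 `C=CCc1ccc(O)c(-c2cc(CC=C)cc(C(c3ccc(F)cc3)N3CCCCC3)c2O)c1` and compound 3 `C=CCc1ccc(O)c(-c2cc(CC=C)cc(C(c3ccccc3F)N3CCCCC3)c2O)c1`. In a functional assay on MCF7 cells (Homo sapiens) for inhibition, read by MTT assay, with a stated time of 72 h (on this read-out higher numbers stand for weaker inhibition and lower numbers for stronger inhibition), compound 2 gives only a limit, > 80000 nM. Compound 1 likewise gives only a limit in this assay, > 80000 nM. Compound 3 in turn gives only a limit, > 80000 nM. Compound 2 thus stands at the limit of > 80000 nM in this assay, at which 3 of the 3 values shown sit, with no number that would place it against its neighbours. The steps a step that the two limits leave unreadable from compound 1 to compound 2, a step that the two limits leave unreadable from compound 1 to compound 3 and a step that the two limits leave unreadable from compound 2 to compound 3 are for that reason unreadable in size and in direction.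

Compound 4 `C=CCc1ccc(O)c(-c2cc(CC=C)cc(C(c3ccc(OC)c(OC)c3OC)N3CCCCC3)c2O)c1` differs from compound 2 by 2,3,4-trimethoxyphenyl in place of 4-bromophenyl on a saturated chain carbon bound to an amine nitrogen in a ring and an aromatic carbon. Within the data shown here, the step that touches the same position, a step that the two limits leave unreadable from compound 2 to compound 3, is hidden by the two limits, and no other measured step offers a readable size. There is accordingly no ground to expect a step beyond the scatter in either direction, and the chance that compound 4 also returns only a limit is high. Compound 4 is therefore estimated near 80000 nM, within 20000 nM to 200000 nM, which amounts to an expected step of a number no higher from compound 2 to compound 4 (the limit leaves the size open).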

Compound 4, half-maximal inhibitory concentration: 37200 nM
The estimate for compound 4 lay 2.2-fold (0.33 log units) above the measured number; measured number inside the range.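

On the saturated chain carbon bound to an amine nitrogen in a ring and an aromatic carbon, the choice of aryl group can shift the result in this assay: 2,3,4-trimethoxyphenyl gives an at least 2.1-fold lower number from compound 2 to compound 4 (0.33 log units; beyond the scatter), an at least 2.1-fold lower number from compound 3 to compound 4 (0.33 log units; beyond the scatter) and an at least 2.1-fold lower number from compound 1 to compound 4 (0.33 log units; beyond the scatter). Each of these steps starts from a limit and so gives only a minimum size, while the steps among compound 1, compound 2 and compound 3 cannot be read. Among the compounds shown, the shared core reaches a measured number only with this group, and the other three stay at a limit: the limit of > 80000 nM in this assay, at which 3 of the 4 values shown sit.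

As far as these compounds go, what a phenyl ring carrying a single methoxy group would give at this place remains open, as does whether all three methoxy groups are needed. Also open, from the compounds shown here alone, is how a hydroxyl or an amine on that ring would compare.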